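The source may report more compounds than this note shows. Statements on the series, on what has been measured and on what is new or still open speak of the compounds shown alone.

Compound 3, `COc1ccc(-c2cn(-c3cccc(C(=O)/C=C/c4cc(OC)c(OC)c(OC)c4)c3)c(=O)[nH]2)cc1`, stands second highest among three numbers in a functional assay on LOX IMVI cells (Homo sapiens) for inhibition (a higher number here means a weaker inhibitor of growth, a lower number a stronger inhibitor of growth), where compound 3 gives 720 nM. Its nearest neighbour is compound 2, `COc1cc(/C=C/C(=O)c2cccc(-n3cc(-c4ccccc4)[nH]c3=O)c2)cc(OC)c1OC`, with 480 nM; furthest is compound 1, `COc1cc(/C=C/C(=O)c2cccc(-n3cc(-c4ccc(Cl)cc4)[nH]c3=O)c2)cc(OC)c1OC`, with 1720 nM. Compound 4, `COc1cc(/C=C/C(=O)c2cccc(-n3cc(-c4cc(OC)c(OC)c(OC)c4)[nH]c3=O)c2)cc(OC)c1OC`, differs from compound 3 by 3,4,5-trimethoxyphenyl in place of 4-methoxyphenyl on an aromatic carbon. Among the measured compounds shown here, two measured steps bear on adding methoxy at this ring: a 2.4-fold lower number from compound 1 to compound 3 (0.38 log units; beyond the scatter), and a 1.5-fold higher number from compound 2 to compound 3 (0.18 log units; within the scatter). Adding further methoxy groups on this ring has thus given at most a modest lowering and sometimes none beyond the scatter, so for compound 4 a step of a 1.2-fold lower number from compound 3 to compound 4 (0.08 log units; within the scatter) is expected in this assay. Compound 4 is therefore estimated at 600 nM, with a range from 250 nM to 1500 nM.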

Compound 4, concentration for 50% growth inhibition: 1230 nM
For compound 4 the middle estimate is 2.1-fold (0.31 log units) below the measured one, within the range that was stated.
By their numbers in this assay, from the lowest: compounds 2, 3, 4 and 1 (each within the scatter of the next, the first and the last beyond it).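

Replacing 4-methoxyphenyl with 3,4,5-trimethoxyphenyl gives a 1.7-fold higher number from compound 3 to compound 4 (0.23 log units; within the scatter) in this assay and so leaves the number within the scatter of compound 3. Replacing phenyl with the same group gives a 2.6-fold higher number from compound 2 to compound 4 (0.41 log units; beyond the scatter) and makes it the first methoxy-bearing ring here to stand beyond the scatter from phenyl. Replacing 4-chlorophenyl with it gives a 1.4-fold lower number from compound 1 to compound 4 (0.15 log units; within the scatter) and stays within the scatter. Going by these compounds, whether an amine or a carboxylic acid on this ring would keep the number near that of compound 2 stays open. Nothing at hand explains these numbers.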